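Cyano for propyl on the phenol core, URAT1 inhibition

A few compounds are considered here, and "the series" means these few. Any claim that something is new, unique, unknown or untested is made for them only; others in the source may bear on it.

Two measured compounds frame this step. Compound 1 `N#Cc1cc(C(=O)N2CC=CC2)cc(I)c1O` carries a cyano group and an iodo group on the shared core; in an assay on isolated protein for inhibition of solute carrier family 22 member 12 (Homo sapiens), tested at 3 uM (a lower number here means less inhibition, a higher number more inhibition at the concentration tested (going by the name of the read-out)), compound 1 gives 79%. Compound 2 `CCCc1cc(C(=O)N2CC=CC2)cc(C(F)(F)F)c1O` carries a propyl group and a trifluoromethyl group instead; in this assay compound 2 gives 49%. Compound 2 thus stands lowest of the two numbers, and the nearest number, that of compound 1, lies beyond the usual scatter above it.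

Compound 3 `N#Cc1cc(C(=O)N2CC=CC2)cc(C(F)(F)F)c1O` is not yet measured. It differs from compound 2 in one place: cyano in place of propyl on an aromatic carbon, on an aromatic carbon of a six-membered aromatic ring of carbon only, ortho to a hydroxy group.

For the measured compounds named here, no step between measured compounds is available for this change, so its size is uncertain. Compound 3 shares its cyano group with compound 1, whose value 79% is the higher of the two, so a rise beyond the scatter is expected. The estimate for compound 3 in this assay is 68%, with a range from 50% to 85%. The expected step is a number 19 percentage points higher from compound 2 to compound 3 (beyond the scatter).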

Compound 3, a percentage reported as inhibition, at one concentration (the size of the read-out at that concentration, not a potency): 83%
The estimate for compound 3 lay 15 percentage points below the measured number; low and high end bracket the measured number.
By their numbers in this assay, from the lowest: compound 2; then compounds 1 and 3 (each within the scatter of the next).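

Notes on the position ortho to a hydroxy group: with trifluoromethyl held constant, cyano in place of propyl on an aromatic carbon now has a direct reading in this assay, namely a number 34 percentage points higher from compound 2 to compound 3 (beyond the scatter), so this position strongly affects the read-out at the concentration tested. With cyano held constant, trifluoromethyl in place of iodo on an aromatic carbon gives a number 4 percentage points higher from compound 1 to compound 3 (within the scatter), so this second change does not separate the two compounds, and of the two single-place changes only the cyano for propyl change produces a step beyond the scatter. Nothing available accounts for the size of the step, and the reason for it remains unexplained.

From the compounds shown here alone, how a methyl group, a carboxylic acid or an amine would read at the position ortho to a hydroxy group remains open, so two groups give no trend for this position. The effect of trifluoromethyl in place of iodo is also known only with cyano present, and this assay reports inhibition at one concentration, which leaves potency open.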